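Swapping the furan attachment point in a dihydropyrimidinone series

A few compounds are considered here, and "the series" means these few. Any claim that something is new, unique, unknown or untested is made for them only; others in the source may bear on it.

Compound 1 `CC1=C(C(N)=O)C(c2ccoc2)NC(=O)N1` gives 2% in an assay on membranes from HeLa cells for displacement of a labelled ligand from adenosine receptor A3 (Homo sapiens), read by scintillation counting, with a stated time of 180 min, tested at 1 uM; a lower number here means less inhibition, a higher number more inhibition at the concentration tested (going by the name of the read-out). Compound 2 `CCC(C)OC(=O)C1=C(C)NC(=O)NC1c1ccco1` gives 3% in this assay. Compound 2 has the highest of the two numbers seen so far, but compound 1 sits within the usual scatter of it, so the two cannot be told apart. Compound 3 `CCC(C)OC(=O)C1=C(C)NC(=O)NC1c1ccoc1` has not yet been measured. It differs from compound 2 only in the change (furan-3-yl in place of furan-2-yl on a saturated ring carbon). With both known compounds near zero, the expected step from compound 2 to compound 3 is no change at the digits printed from compound 2 to compound 3 (within the scatter), meaning no change beyond the scatter. For compound 3 the estimate in this assay is 3%, with a range of -5% to 12%.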

Compound 3, a percentage reported as inhibition, at one concentration (the size of the read-out at that concentration, not a potency): 11%
Estimate against measurement, compound 3: 8 percentage points below, within the range that was stated.
By their numbers in this assay, from the lowest: compounds 1, 2 and 3 (each within the scatter of the next).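

Placing furan-3-yl in place of furan-2-yl on the saturated ring carbon gives a number 8 percentage points higher from compound 2 to compound 3 (within the scatter) in this assay, so at this position the swap of attachment point shows no effect that can be told from the scatter. Sec-butoxy in place of amino on the carbonyl carbon gives a number 9 percentage points higher from compound 1 to compound 3 (within the scatter), so this second change also stays within the scatter. Nothing available bears on these numbers.

From the compounds shown here alone, it remains open whether a phenyl ring on the saturated ring carbon, or a carboxylic acid or longer chain on the carbonyl carbon, would give a step beyond the scatter.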